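Compound 3 to compound 4: a new carboxyphenyl group

The source may report more compounds than this note shows. Statements on the series, on what has been measured and on what is new or still open speak of the compounds shown alone.

In an ADME assay on a cell-free system (plasma, Rattus norvegicus) for metabolic stability, read by LC-MS, with a stated time of 1 h, at 37 degrees C, tested at 100 uM (a higher number here means that more of the compound is left, a lower number that less of the compound is left), compound 1 `O=C1c2ccc(OCc3cccc(-c4ccc(Cl)cc4F)c3)cc2CN1C1CCCC1` has "not determined" (no result reported). Compound 2 `COc1ccc(C(=O)O)cc1-c1cccc(COc2ccc3c(c2)CN(C2CCCC2)C3=O)c1` gives 100%, and compound 3 `COc1ccc(-c2cccc(COc3ccc4c(c3)CN(C3CCCC3)C4=O)c2)cc1C(=O)O` gives 100%, which leaves compound 3 level with compound 2.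

Compound 4 `O=C(O)c1ccc(-c2cccc(COc3ccc4c(c3)CN(C3CCCC3)C4=O)c2)c(Cl)c1` is the next to be measured in this assay. The change is 4-carboxy-2-chlorophenyl in place of 3-carboxy-4-methoxyphenyl on an aromatic carbon.

Within the data shown here, only one measured step bears on this, no change at the digits printed from compound 2 to compound 3 (within the scatter), and it exchanged 5-carboxy-2-methoxyphenyl for 3-carboxy-4-methoxyphenyl. Among the measured compounds shown here, no measured compound carries 4-carboxy-2-chlorophenyl, so this support is limited. The expected result is a number 3 percentage points lower from compound 3 to compound 4 (within the scatter), with no shift beyond the scatter in either direction. The estimate for compound 4 is 97%, with an expected range of 85% to 100%.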

Compound 4, percent of the compound remaining: 100%
Beside the measured number, compound 4's estimate is 3 percentage points below it, within the range that was stated.
By their numbers in this assay, from the lowest: compounds 2, 3 and 4 (each within the scatter of the next).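

In this assay the change shows no change at the digits printed from compound 3 to compound 4 (within the scatter) and no change at the digits printed from compound 2 to compound 4 (within the scatter). At this position on an aromatic carbon, a chlorine-bearing carboxyphenyl group therefore reads the same as both methoxy-bearing carboxyphenyl groups, so the methoxy group is not needed for this reading. Nothing available explains this outcome. On these data alone, all three compounds with a number carry a carboxylic acid on this ring, so the reading with an amine or a tetrazole in its place remains open.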